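Shortening the Alkyl Chain on a Nucleoside Helicase Inhibitor

This account rests on a few compounds, and the source may have more. Where it says the series, first, only, none or still open, it means among the compounds named here.

Compound 1 `CCCCCCCCCCCCNc1nc(O)c2ncnc-2c(O)n1`: > 500 ug/mL, a limit of the assay rather than a number.
Compound 2 `CCCCCCCCCCCCCCCCNc1nc(=O)c2ncn([C@@H]3O[C@H](CO)[C@@H](O)[C@H]3O)c2c(=O)[nH]1`: 30 ug/mL.

For the measured compounds named here, in an assay on isolated protein for inhibition of ATP-dependent RNA helicase SUPV3L1, mitochondrial (Homo sapiens) (a higher number here means a weaker inhibitor, a lower number a stronger inhibitor), compound 2 gives 30 ug/mL, the only number measured so far. Compound 1 reached only (the limit of > 500 ug/mL in this assay, at which 1 of the 2 values shown sits). Compound 3 `CCCCCCCCCCNc1nc(=O)c2ncn([C@@H]3O[C@H](CO)[C@@H](O)[C@H]3O)c2c(=O)[nH]1` differs from compound 2 by hydrogen in place of hexyl on a saturated chain carbon, ten or more bonds along the chain from a nitrogen on an aromatic ring. Going by the values given here, no measured pair differs in just one place, so the size of such a step is not yet known; a cut of this length in the chain is expected to weaken inhibition by more than the scatter in this assay. Compound 3 is estimated at 100 ug/mL, between 30 ug/mL and 500 ug/mL, which means an expected step of a 3.3-fold higher number from compound 2 to compound 3 (0.52 log units; beyond the scatter).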

Compound 3, half-maximal inhibitory concentration: 500 ug/mL
The estimate for compound 3 lay 5.0-fold (0.70 log units) below the measured number; low and high end bracket the measured number.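

In this assay, hydrogen in place of hexyl on a saturated chain carbon, ten or more bonds along the chain from a nitrogen on an aromatic ring, gives a 17-fold higher number from compound 2 to compound 3 (1.22 log units; beyond the scatter). For the compounds shown here, this is the first measured single change, and it shows that chain length alone matters strongly here, with the rest of the structure unchanged. Little room remains for reading still shorter chains in this assay: the limit of > 500 ug/mL in this assay, at which 1 of the 3 values shown sits.

On these data alone, whether a longer chain would lower the number further remains open. So does whether an amine or a carboxylic acid in place of hexyl would keep the strength of compound 2.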